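This account rests on a few compounds, and the source may have more. Where it says the series, first, only, none or still open, it means among the compounds named here.

Measured so far in a physicochemical assay for lipophilicity, read by HPLC, at pH 7.5; on this read-out higher numbers stand for higher lipophilicity and lower numbers for lower lipophilicity
- compound 1 `CC[C@@H](Nc1c(C#N)c(-c2ccc(-c3ccncc3C)cc2)nc2cnccc12)C(N)=O` gives 2
- compound 2 `CC[C@@H](Nc1c(C#N)c(-c2ccc(-c3ccccc3N(C)C)cc2)nc2cnccc12)C(N)=O` gives 3.2
- compound 3 `CC[C@@H](Nc1c(C#N)c(-c2ccc(-c3cccnc3C)cc2)nc2cnccc12)C(N)=O` gives 1.9

Compound 3 sits at the low end of the three, level with compound 1 within the scatter, as a number 0.10 log units lower from compound 1 to compound 3 (within the scatter) shows. Compound 2 stands clear of both, with a number 1.30 log units lower from compound 2 to compound 3 (beyond the scatter) and a number 1.20 log units higher from compound 1 to compound 2 (beyond the scatter).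

Compound 4 `CC[C@@H](Nc1c(C#N)c(-c2ccc(-c3ccccc3C)cc2)nc2cnccc12)C(N)=O` is still unmeasured. The change is 2-methylphenyl in place of 2-methylpyridin-3-yl on an aromatic carbon, para to a large group. Within the data shown here, no measured pair makes this exact exchange. The nearest guide is compound 2, which carries a six-membered aromatic ring of carbon only and reads 3.2, though its 2-(dimethylamino)phenyl differs from 2-methylphenyl. A large rise is therefore expected, and the estimate is a number 1.30 log units higher from compound 3 to compound 4 (beyond the scatter). Compound 4 is expected at 3.2 (range 2.8 to 3.6).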

Compound 4, distribution coefficient: 3
Compound 4: middle estimate off by 0.20 log units, on the high side; low and high end bracket the measured number.
By their numbers in this assay, from the lowest: compounds 3 and 1 (each within the scatter of the next); then compounds 4 and 2 (each within the scatter of the next).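

In this assay, 2-methylphenyl, a six-membered aromatic ring of carbon only, stands clear of both methylpyridinyl compounds (a number 1.10 log units higher from compound 3 to compound 4 (beyond the scatter); a number 1.00 log units higher from compound 1 to compound 4 (beyond the scatter)). With the carbon-only ring kept, methyl in place of dimethylamino stays within the scatter (a number 0.20 log units lower from compound 2 to compound 4 (within the scatter)), so the four compounds form two pairs, those with a ring of carbon only and those with a ring hetero atom. Nothing at hand explains this split.

Still open, on these data alone, is whether the split holds for other groups on the carbon-only ring, such as methoxy, chloro or a carboxylic acid. As far as these compounds go, it is equally open where a saturated ring such as morpholine would fall in this place.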